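This account rests on a few compounds, and the source may have more. Where it says the series, first, only, none or still open, it means among the compounds named here.

Measured set, with values in a functional assay on A549 cells (Homo sapiens) for antiproliferative activity, read by MTT assay, with a stated time of 72 h; on this read-out higher numbers stand for weaker inhibition and lower numbers for stronger inhibition:
Compound 1 `O=C(Nc1ccc(Nc2nccc(NC3CCCC3)n2)cc1)NC1CCCCC1` gives 5320 nM.
Compound 2 `O=C(Nc1ccc(Nc2nccc(NC3CCCC3)n2)cc1)Nc1cccc(C(F)(F)F)c1` gives 4900 nM.
Compound 3 `O=C(Nc1ccc(Cl)cc1)Nc1ccc(Nc2nccc(NC3CCCC3)n2)cc1` gives 11800 nM.

Compound 3 stands highest of the three numbers; its nearest neighbour is compound 1, and the two steps onto compound 3, a 2.2-fold higher number from compound 1 to compound 3 (0.35 log units; beyond the scatter) and a 2.4-fold higher number from compound 2 to compound 3 (0.38 log units; beyond the scatter), are both modest yet beyond the scatter. Compound 4 `O=C(CC1CCCCC1)Nc1ccc(Nc2nccc(NC3CCCC3)n2)cc1` remains unmeasured. It differs from compound 3 by cyclohexylmethyl in place of (4-chlorophenyl)amino on a carbonyl carbon. Going by the values given here, no measured step alters a group on the carbonyl carbon in this way; the nearest bearing comes from the amide-type nitrogen, where cyclohexyl gave the lower number, as a 2.2-fold higher number from compound 1 to compound 3 (0.35 log units; beyond the scatter) shows, while a 1.1-fold lower number from compound 1 to compound 2 (0.04 log units; within the scatter) lies within the scatter. A modest step toward a lower number is therefore expected, a 2.0-fold lower number from compound 3 to compound 4 (0.29 log units; within the scatter), with wide uncertainty. Compound 4 is estimated at 6000 nM, range 2500 nM to 15000 nM.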

Compound 4, half-maximal inhibitory concentration: 3940 nM
For compound 4 the middle estimate is 1.5-fold (0.18 log units) above the measured one, and the stated range covers the measured number.
By their numbers in this assay, from the lowest: compounds 4, 2 and 1 (each within the scatter of the next); then compound 3.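

Going by these compounds alone, on the carbonyl carbon, the amino nitrogen of the earlier compounds proves dispensable in this assay: with cyclohexylmethyl there, a 1.4-fold lower number from compound 1 to compound 4 (0.13 log units; within the scatter) and a 1.2-fold lower number from compound 2 to compound 4 (0.09 log units; within the scatter) both stay within the scatter. Only the comparison with the 4-chlorophenyl compound separates, at a 3.0-fold lower number from compound 3 to compound 4 (0.48 log units; beyond the scatter), so this change gives a clear gain over one of the three earlier compounds only. No measurement shown here explains these steps.

Open, as far as these compounds go, is whether benzyl on the carbonyl carbon would behave like cyclohexylmethyl. A longer chain to the cyclohexyl ring, or an amine on that ring, also remains untested in the compounds shown.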